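Fluoro in place of hydrogen on the compound 2 scaffold

The source may hold more compounds than are shown below. What is called first, only, known or untested is meant among the compounds shown, and "the series" means these compounds.

Measured so far in a functional assay on HCT-116 cells (Homo sapiens) for antiproliferative activity, read by MTT assay, with a stated time of 48 h; a higher number here means a weaker inhibitor, a lower number a stronger inhibitor

- compound 1 `COc1ccc(N(C)c2ccnc(Cl)n2)cc1OCCCCBr` gives 1140 nM
- compound 2 `COc1ccc(N(C)c2cc(C)nc(C)n2)cc1` gives 1320 nM

Compound 2 at 1320 nM and compound 1 at 1140 nM lie within the scatter of each other in this assay and no order can be drawn between them. Compound 3 `COc1ccc(N(C)c2cc(C)nc(C)n2)cc1F` has not yet been measured. Its difference from compound 2 is fluoro in place of hydrogen on an aromatic carbon and in words this is fluoro in place of hydrogen on an aromatic carbon, ortho to a methoxy group.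

Going by the values given here, no two measured compounds differ in one place only, so the series offers no measured step against which to scale this change. The expectation therefore rests on compound 2 at 1320 nM alone, and no shift beyond the scatter is expected in either direction. The expected step is a 1.1-fold lower number from compound 2 to compound 3 (0.04 log units; within the scatter) and it stays within the scatter. Compound 3 is estimated at 1200 nM with an expected range from 500 nM to 2800 nM until a measurement is in hand.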

Compound 3, half-maximal inhibitory concentration: 584 nM
The estimate for compound 3 lay 2.1-fold (0.31 log units) above the measured number, and the stated range covers the measured number.
By their numbers in this assay, from the lowest: compounds 3, 1 and 2 (each within the scatter of the next, the first and the last beyond it).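

In this assay, going by these compounds alone, fluoro in place of hydrogen on an aromatic carbon, ortho to a methoxy group, gives a 2.3-fold lower number from compound 2 to compound 3 (0.35 log units; beyond the scatter) and so provides the first single-place step that can be read. The step is modest, yet it shows that this aromatic carbon is not indifferent to substitution: one fluorine atom entering in place of a hydrogen atom, with no ring and no net charge added, is enough to move the number beyond the scatter. The data at hand give no measured basis for explaining why the number moves.

On these data alone, whether this step is particular to fluoro or would also follow from other small groups on the same carbon stays open, and chloro, methyl, hydroxyl or an amine there would separate these readings. Also open, as far as these compounds go, is whether fluoro on this carbon carries a step of similar size on the core of compound 1, where a longer chain ending in bromine stands on the same aromatic ring and the other ring carries different groups.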